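The source may hold more compounds than are shown below. What is called first, only, known or untested is meant among the compounds shown, and "the series" means these compounds.

Working notes on the series. The shared core carries a pyridine on the double-bonded ring carbon of compound 1 `C[C@@H](O[C@H]1CN2C(=O)C=C(c3ccncc3)CC2[C@@H]1c1ccc(F)cc1)c1cc(C(F)(F)F)cc(C(F)(F)F)c1`, which in an assay on CHO cells for displacement of a labelled ligand from Substance-P receptor (Homo sapiens) (a higher number here means a weaker inhibitor, a lower number a stronger inhibitor), gives 0.14 nM. Compound 2 `C[C@@H](O[C@H]1CN2C(=O)C=C(c3cc[n+]([O-])cc3)CC2[C@@H]1c1ccc(F)cc1)c1cc(C(F)(F)F)cc(C(F)(F)F)c1` has the pyridine oxide in its place and gives 0.1 nM in this assay, so a 1.4-fold lower number from compound 1 to compound 2 (0.15 log units; within the scatter). Compound 3 `Cc1cc(C2=CC(=O)N3C[C@H](O[C@H](C)c4cc(C(F)(F)F)cc(C(F)(F)F)c4)[C@@H](c4ccc(F)cc4)C3C2)ccn1` carries a methyl on the pyridine and gives 0.51 nM; it stands highest of the three numbers, with a 3.6-fold higher number from compound 1 to compound 3 (0.56 log units; beyond the scatter) and a 5.1-fold higher number from compound 2 to compound 3 (0.71 log units; beyond the scatter).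

Compound 4 `COc1cc(C2=CC(=O)N3C[C@H](O[C@H](C)c4cc(C(F)(F)F)cc(C(F)(F)F)c4)[C@@H](c4ccc(F)cc4)C3C2)ccn1` differs from compound 3 in one place: methoxy in place of methyl on an aromatic carbon. Going by the values given here, no measured step exchanges methoxy for methyl, so the two steps that bear on it do so only indirectly: the methyl entering next to the ring nitrogen cost a modest step from compound 1 to compound 3, while the change on the ring nitrogen itself from compound 1 to compound 2 stayed within the scatter. Substitution at this ring position has therefore been tolerated with only modest loss, and methoxy in place of methyl is expected to behave in the same range. The expected step is a 1.6-fold higher number from compound 3 to compound 4 (0.20 log units; within the scatter), in this assay, not beyond the scatter with confidence. For compound 4 the estimate in this assay is 0.8 nM, within 0.25 nM to 2.5 nM.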

Compound 4, half-maximal inhibitory concentration: 1.1 nM
Compound 4: middle estimate off by 1.4-fold (0.14 log units), on the low side; the measured number falls inside the stated range.
By their numbers in this assay, from the lowest: compounds 2 and 1 (each within the scatter of the next); then compound 3; then compound 4.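

Going by these compounds alone, the first direct exchange at this position, methoxy in place of methyl on an aromatic carbon next to the ring nitrogen, gives a 2.2-fold higher number from compound 3 to compound 4 (0.33 log units; beyond the scatter) in this assay, so the loss seen with methyl continues when methoxy enters. Set against the pyridine without a substituent, methoxy gives a 7.9-fold higher number from compound 1 to compound 4 (0.90 log units; beyond the scatter), and set against the pyridine oxide it gives an 11-fold higher number from compound 2 to compound 4 (1.04 log units; beyond the scatter), the only step in the series so far printed as large. Both groups tried on this aromatic carbon, methyl in a 3.6-fold higher number from compound 1 to compound 3 (0.56 log units; beyond the scatter) and methoxy, thus raise the number beyond the scatter, whereas the change on the ring nitrogen in a 1.4-fold lower number from compound 1 to compound 2 (0.15 log units; within the scatter) stays within it, though this contrast rests on these four compounds alone. No measurement shown here accounts for these steps.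

As far as these compounds go, it remains open whether an amine or a fluorine on this aromatic carbon would stay within the scatter of compound 1, and whether a longer chain such as ethoxy would carry the rise further. From the compounds shown here alone, it is also open how a group on this carbon would read in combination with the pyridine oxide of compound 2.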